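The source may report more compounds than this note shows. Statements on the series, on what has been measured and on what is new or still open speak of the compounds shown alone.

Notes on the series around the shared core of compound 1 `COc1ccc(Cl)cc1S(=O)(=O)Nc1ccc(-c2nc3ccccc3o2)cc1`. In an ADME assay on HEK293 cells (Homo sapiens) for cytotoxicity, read by resazurin assay, with a stated time of 48 h (on this read-out higher numbers stand for lower toxicity in this test and lower numbers for higher toxicity in this test), compound 1 gives 75000 nM. Compound 2 `Cc1ccccc1S(=O)(=O)Nc1ccc(-c2nc3ccccc3o2)cc1` returns a limit of this assay, > 100000 nM. Compound 3 `O=[N+]([O-])c1cc(S(=O)(=O)Nc2ccc(-c3nc4ccccc4o3)cc2)ccc1Cl` gives 85000 nM in this assay, the highest of the two numbers, and compound 1 sits within the scatter of it. For the measured compounds named here, the single measured step, an at least 1.3-fold higher number from compound 1 to compound 2 (0.12 log units; that floor lies within the scatter), swapped the aryl group on the sulfonyl sulfur; one of its values is a limit (the limit of > 100000 nM in this assay, at which 1 of the 3 values shown sits), so its size is known only as a floor within the scatter. Compound 4 `O=S(=O)(Nc1ccc(-c2nc3ccccc3o2)cc1)c1ccc(Cl)c(Cl)c1` differs from compound 3 by chloro in place of nitro on an aromatic carbon. No step in this assay has been shown beyond the scatter, so none is expected here. The expected step is a 1.1-fold higher number from compound 3 to compound 4 (0.02 log units; within the scatter). Compound 4 is expected to give 90000 nM, within a range from 45000 nM to 180000 nM.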

Compound 4, half-maximal cytotoxic concentration: > 100000 nM
Compound 4: only a limit was reported (the forecaster's own chance of this, stated with the estimate: 35%); at least 1.1-fold (0.04 log units) between middle value and limit.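

For the compounds shown here, on this aromatic carbon, ortho to a chloro group, chloro in place of nitro gives an at least 1.1-fold higher number from compound 3 to compound 4 (0.07 log units; that floor lies within the scatter), the first reading for a change at this position, and it shows no step beyond the scatter. Exchanging the whole aryl group on the sulfonyl sulfur gives an at least 1.3-fold higher number from compound 1 to compound 4 (0.12 log units; that floor lies within the scatter), while the step between compound 2 and compound 4 cannot be read. Both readable sizes remain floors, and the limit now recurs in the series: the limit of > 100000 nM in this assay, at which 2 of the 4 values shown sit.

As far as these compounds go, what an amine or a carboxylic acid on this aromatic carbon would give in this assay stays open. So does whether any change to the aryl group moves the number beyond the scatter.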